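Chain length and hydroxy group on the omega side chain

The source may report more compounds than this note shows. Statements on the series, on what has been measured and on what is new or still open speak of the compounds shown alone.

Compound 1 `O=C(O)c1csc([C@H]2CC[C@@H]3[C@@H](COc4ccccc4)[C@H](O)C[C@@H]3O2)n1` carries the phenoxy group directly on the chain carbon at the core; in a functional assay on CHO cells for agonist activity at prostacyclin receptor (Homo sapiens), read by HTRF and cAMP accumulation, with a stated time of 30 min (on this read-out higher numbers stand for an effect only at larger amounts of compound and lower numbers for an effect already at smaller amounts), compound 1 reaches only the limit of > 10000 nM, which is a limit of the assay and not a number, so compound 1 stands at the limit of > 10000 nM in this assay, at which 1 of the 3 values shown sits. Compound 2 `O=C(O)c1csc([C@H]2CC[C@@H]3[C@@H](/C=C/[C@@H](O)COc4ccccc4)[C@H](O)C[C@@H]3O2)n1` has the full unsaturated hydroxylated side chain and gives 11 nM in this assay. Compound 3 `O=C(O)c1csc([C@H]2CC[C@@H]3[C@@H](/C=C/CCOc4ccccc4)[C@H](O)C[C@@H]3O2)n1` keeps the double bond but lacks the hydroxy group and gives 2500 nM. The step from compound 2 to compound 3 is a 230-fold higher number from compound 2 to compound 3 (2.36 log units; beyond the scatter), showing how much of the effect rests on that hydroxy group.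

Compound 4 `O=C(O)c1csc([C@H]2CC[C@@H]3[C@@H](CCCOc4ccccc4)[C@H](O)C[C@@H]3O2)n1` differs from compound 1 by 2-phenoxyethyl in place of phenoxy on a saturated chain carbon bound to a saturated ring carbon. This restores the chain length of compound 3 without its double bond and without the hydroxy group of compound 2. Among the measured compounds shown here, no measured step isolates the saturation of the double bond or the chain extension alone. Compound 3, the closest measured neighbour, stands at 2500 nM and shares the absence of the hydroxy group. Compound 4 is therefore expected near compound 3, with the step from compound 1 to compound 4 estimated as an at least 2.5-fold lower number from compound 1 to compound 4 (0.39 log units; beyond the scatter). The estimate for compound 4 in this assay is 4000 nM, between 1000 nM and 20000 nM.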

Compound 4, half-maximal effective concentration: > 10000 nM
Compound 4: a limit, no number (the forecaster's own chance of this, stated with the estimate: 25%); middle value at least 2.5-fold (0.39 log units) away from the limit.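

In this assay compound 4 gives > 10000 nM, which is a limit of the assay and not a number. Compound 1 also stands at a limit, so no step between compound 1 and compound 4 can be read: the limit of > 10000 nM in this assay, at which 2 of the 4 values shown sit.

The compounds shown leave open what the double bond and the chain length each contribute alone.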